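This account rests on a few compounds, and the source may have more. Where it says the series, first, only, none or still open, it means among the compounds named here.

Working notes on the series.

Of the compounds shown here, two have been measured so far. Compound 1 `Cc1ccc(C(=O)Nc2nc3cc(C)cc(C)c3s2)cc1` gives 2.17 ug/mL in a functional assay on SK-HEP1 cells (Homo sapiens) for antiproliferative activity, read by sulforhodamine B assay; on this read-out higher numbers stand for weaker inhibition of growth and lower numbers for stronger inhibition of growth. Compound 2 `Cc1cc(C)c2sc(NC(=O)c3ccc(C#N)cc3)nc2c1` gives 1.18 ug/mL in this assay. The only step available, from compound 1 to compound 2, was a 1.8-fold lower number from compound 1 to compound 2 (0.26 log units; within the scatter), so on the numbers shown compound 2 sits alongside compound 1 rather than apart from it, and nothing in the pair separates the two beyond the scatter.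

The next compound, compound 3 `COc1ccc(C(=O)Nc2nc3cc(C)cc(C)c3s2)cc1`, differs from compound 2 in one place: methoxy in place of cyano on an aromatic carbon. Within the data shown here, no measured step involves a methoxy group, so the only point of reference is the exchange at the same place between compound 1 and compound 2, which stayed within the scatter. Among the measured compounds shown here, with the shared core and the amide untouched, and the only recorded change at this position having moved the number so little, no step beyond the scatter is expected in this assay for compound 3, in either direction.

The estimate for compound 3 is therefore 1.8 ug/mL, with a range of 0.7 ug/mL to 4.5 ug/mL, which corresponds to an expected step of a 1.5-fold higher number from compound 2 to compound 3 (0.18 log units; within the scatter).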

Compound 3, concentration for 50% growth inhibition: > 10 ug/mL
Compound 3: a limit, no number; the forecaster's own chance of this, stated with the estimate: 5%; middle value at least 5.5-fold (0.74 log units) away from the limit.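

Compound 3 reads as a limit of the assay and not as a number: the limit of > 10 ug/mL in this assay, at which 1 of the 3 values shown sits. The earlier pair suggested little sensitivity at this position, but it is not indifferent in this assay, since methoxy in place of cyano gives an at least 8.4-fold higher number from compound 2 to compound 3 (0.92 log units; beyond the scatter), and methoxy in place of methyl gives an at least 4.6-fold higher number from compound 1 to compound 3 (0.66 log units; beyond the scatter). Both steps lie beyond the scatter, although cyano and methoxy have the same heavy-atom count and the same counts of hydrogen-bond donors and acceptors, so these counts do not account for the separation of compound 3 from compound 1 and compound 2.

As far as these compounds go, the true size of both steps stays open. Three compounds with a single change of group at this place show that the steps exist and nothing more. Also open, from the compounds shown here alone, is whether the weaker growth inhibition belongs to methoxy alone or extends to other groups on this aromatic carbon, such as a hydroxyl, an amine, ethoxy or a longer ether chain, or a carboxylic acid.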